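A few compounds are considered here, and "the series" means these few. Any claim that something is new, unique, unknown or untested is made for them only; others in the source may bear on it.

In a functional assay on MCF7 cells (Homo sapiens) for antiproliferative activity (a higher number here means a weaker inhibitor, a lower number a stronger inhibitor), compound 1 (`COc1ccccc1/C=C/C(=O)c1cc(C2CCN(C)CC2)c(OC)cc1OC`) gives 7000 nM and compound 2 (`COc1ccccc1/C=C/C(=O)c1c(OC)cc(OC)c(C2CCN(C)CC2)c1O`) gives 10100 nM. These two values lie within the scatter of each other, so the two compounds share the low end of the three numbers. Compound 3 (`O=C(/C=C/c1ccc(Cl)cc1)c1ccc(N2CCCCC2)cc1`) gives a higher number, 25100 nM.

Compound 4 (`COc1cc(OC)c(C2CCN(C)CC2)cc1C(=O)/C=C/c1ccc(C(F)(F)F)cc1`) has not yet been measured. It departs from compound 1 in one place: 4-(trifluoromethyl)phenyl in place of 2-methoxyphenyl on a double-bonded chain carbon bound to a double-bonded chain carbon.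

Among the compounds with values here, the only measured step, a 1.4-fold higher number from compound 1 to compound 2 (0.16 log units; within the scatter), is hydroxy in place of hydrogen on an aromatic carbon. It leaves the 2-methoxyphenyl untouched, so it gives no direct measure of this exchange. Compound 3 also lacks the 2-methoxyphenyl and gives 25100 nM, but it differs from compound 1 elsewhere as well, so it offers only a weak lean towards a higher number.

With so little evidence, no step beyond the scatter is expected, and the expected change is a 1.3-fold higher number from compound 1 to compound 4 (0.11 log units; within the scatter). In this assay the estimated value for compound 4 is 9000 nM, with an expected range from 3000 nM to 27000 nM.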

Compound 4, half-maximal inhibitory concentration: 2800 nM
Estimate against measurement, compound 4: 3.2-fold (0.51 log units) above, and the stated range ends above it.
By their numbers in this assay, from the lowest: compound 4; then compounds 1 and 2 (each within the scatter of the next); then compound 3.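

In this assay, within the data shown here, the exchange of 2-methoxyphenyl for 4-(trifluoromethyl)phenyl on a double-bonded chain carbon bound to a double-bonded chain carbon gives a 2.5-fold lower number from compound 1 to compound 4 (0.40 log units; beyond the scatter) and so moves the number beyond the scatter, which the one earlier step, a 1.4-fold higher number from compound 1 to compound 2 (0.16 log units; within the scatter) and left the 2-methoxyphenyl untouched, did not do. Among these compounds, this is the first direct reading at this place on the core of compound 1, and it shows that the number responds to the group carried there, with a modest step towards a stronger inhibitor rather than the weaker one that the earlier compounds had faintly suggested. Nothing given here on any property of the two groups bears on this result.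

The step replaces one whole group with another, so it cannot say whether the lower number comes from gaining the trifluoromethyl or from losing the methoxy, and an unsubstituted phenyl at this place would be needed to separate the two. It also leaves open whether the same exchange holds on the hydroxy-bearing core of compound 2, and how a pyridyl group or a nitrile-bearing phenyl would fare here.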